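Methyl added on the aryl ether ring: one step as a guide

This account rests on a few compounds, and the source may have more. Where it says the series, first, only, none or still open, it means among the compounds named here.

The measured compounds and their values:
compound 1, `Clc1ccc(Cn2cc(COc3ccccc3)nn2)cc1`, 26.1 ug/mL
compound 2, `Cc1ccc(OCc2cn(Cc3ccc(Cl)cc3)nn2)cc1`, 17.3 ug/mL
compound 3, `O=[N+]([O-])c1cccc(Cn2cc(COc3ccc(Cl)cc3)nn2)c1`, 21.3 ug/mL

Of the compounds shown here, three have been tested in a physicochemical assay, read by spectrophotometry, with a stated time of 30 min; on this read-out higher numbers stand for weaker inhibition and lower numbers for stronger inhibition. Compound 1 has the structure `Clc1ccc(Cn2cc(COc3ccccc3)nn2)cc1` and in this assay compound 1 gives 26.1 ug/mL. Compound 2, `Cc1ccc(OCc2cn(Cc3ccc(Cl)cc3)nn2)cc1`, differs from compound 1 by a single change, (methyl in place of hydrogen on an aromatic carbon), and compound 2 gives 17.3 ug/mL. The step is a 1.5-fold lower number from compound 1 to compound 2 (0.18 log units; within the scatter). Compound 3, `O=[N+]([O-])c1cccc(Cn2cc(COc3ccc(Cl)cc3)nn2)c1`, gives 21.3 ug/mL; the difference between its core and that of compound 1 is not broken down here, and the values of compound 3 and compound 1 lie within the scatter of each other.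

Compound 4, `Cc1cc(OCc2cn(Cc3cccc([N+](=O)[O-])c3)nn2)ccc1Cl`, has not yet been measured. It differs from compound 3 by methyl in place of hydrogen on an aromatic carbon. Within the data shown here, this is the same kind of change as the one from compound 1 to compound 2, but the place is not the same: in compound 2 the methyl sits para to a large group, whereas in compound 4 it sits ortho to a chloro group (1 heavy atom) and meta to a large group. The step expected from compound 3 to compound 4 is a 1.3-fold lower number from compound 3 to compound 4 (0.12 log units; within the scatter), resting on the earlier step of a 1.5-fold lower number from compound 1 to compound 2 (0.18 log units; within the scatter), a small change that stayed within the scatter. Compound 4 is therefore estimated to give 16 ug/mL in this assay, with a likely range from 9 ug/mL to 30 ug/mL.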

Compound 4, half-maximal inhibitory concentration: 15.6 ug/mL
Compound 4: middle estimate off by 1.0-fold (0.01 log units), on the high side; measured number inside the range.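

In this assay, methyl in place of hydrogen on an aromatic carbon gives a 1.4-fold lower number from compound 3 to compound 4 (0.14 log units; within the scatter), and the same kind of change on the core of compound 1 gives a 1.5-fold lower number from compound 1 to compound 2 (0.18 log units; within the scatter), so on both cores the step stays within the scatter. This shows that, across these two pairs, the change carried from one core to the other without producing a step beyond the scatter, even though the methyl of compound 4, ortho to a chloro group and meta to a large group, does not stand in the same place as the methyl of compound 2. It does not show that the methyl has a real effect on either core, or that the two steps reflect a shared effect rather than the ordinary spread of repeated measurements, and no measurement shown bears on why the steps have this size.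

The compounds shown leave open whether an amine, a carboxylic acid or a longer chain on that ring carbon would give a step beyond the scatter. Among these compounds, they also leave open whether the methyl would behave in the same way on any core other than these two, since only two pairs can be compared here.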